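Methylsulfanyl for hydroxymethyl at the assay limit

The source may report more compounds than this note shows. Statements on the series, on what has been measured and on what is new or still open speak of the compounds shown alone.

In an ADME assay on MRC5 cells (Homo sapiens) for cytotoxicity, read by fluorescence, with a stated time of 72 h (a lower number here means a stronger inhibitor, a higher number a weaker inhibitor), compound 1 `CC1(COc2ccc(OC(F)(F)F)cc2)Cn2cc([N+](=O)[O-])nc2O1` gives > 64000 nM, which is a limit and not a number. Compound 2 `CC1(COc2ccc(OC(F)(F)F)cc2)Cn2cc(CO)nc2O1` gives > 64000 nM in this assay, and this is also a limit. Compound 2 thus stands with compound 1 at the limit of > 64000 nM in this assay, at which 2 of the 2 values shown sit. For the measured compounds named here, the only measured step, a step that the two limits leave unreadable from compound 1 to compound 2, offers no size to carry forward.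

Compound 3 `CSc1cn2c(n1)OC(C)(COc1ccc(OC(F)(F)F)cc1)C2` has methylsulfanyl in place of hydroxymethyl on an aromatic carbon. Going by the values given here, since the two measured compounds sit at the limit of > 64000 nM in this assay, at which 2 of the 2 values shown sit, a third compound that changes only this group is expected to stay there too. No shift beyond the scatter is therefore expected in this assay, though any shift that did appear could only be readable toward stronger inhibition. The expected change is a number no higher from compound 2 to compound 3 (the limit leaves the size open). For compound 3 the estimate is 64000 nM, with an expected range of 30000 nM to 64000 nM.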

Compound 3, half-maximal inhibitory concentration: 38000 nM
For compound 3 the middle estimate is 1.7-fold (0.23 log units) above the measured one; the measured number falls inside the stated range.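

In this assay compound 3 gives 38000 nM, the only value among the three shown that is a number and not a limit, so a change on this aromatic carbon can bring a compound in this series into the readable range. Methylsulfanyl in place of hydroxymethyl gives an at least 1.6-fold lower number from compound 2 to compound 3 (0.22 log units; that floor lies within the scatter), and methylsulfanyl in place of nitro gives an at least 1.6-fold lower number from compound 1 to compound 3 (0.22 log units; that floor lies within the scatter); each is only a floor, so the true size of either step remains unknown. Compound 1 and compound 2 remain limits and not numbers: the limit of > 64000 nM in this assay, at which 2 of the 3 values shown sit.

A methoxy group or an amine on this same carbon would show whether the sulfur atom matters here or the group as a whole. Going by these compounds, how far the number of compound 3 depends on the trifluoromethoxy group elsewhere in the molecule also remains open.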